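The compounds below may be only part of what the source reports. "The series", "measured", "known", "first", "only" and "open" are said of these compounds alone.

Of the compounds shown here, three have so far been tested in a functional assay on the whole organism (strain Sprague-Dawley) for inhibition, with Rattus norvegicus as the target; a higher number here means that more compound is needed for the effect, a lower number that less compound is needed. Among the measured compounds shown here, compound 1, `Fc1ccc2ncc(-c3nn[nH]n3)cc2c1`, is the only one with a plain number: in this assay compound 1 gives 50 mg/kg. Compound 2, `COc1ccc2cc(-c3nn[nH]n3)cnc2c1`, gives only a limit of the assay in this assay, > 25 mg/kg. Compound 3, `O=c1c(-c2nn[nH]n2)c[nH]c2c(Br)cccc12`, also gives only a limit of the assay in this assay, > 10 mg/kg.

Where compound 3 stands is therefore not a number but a limit: the limit of > 10 mg/kg in this assay, at which 1 of the 3 values shown sits, and a second limit sits among the three values: the limit of > 25 mg/kg in this assay, at which 1 of the 3 values shown sits. Nothing here says how much more compound 3 would need, only that the assay did not reach an effect.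

Compound 4, `CS(=O)(=O)c1cccc2c(=O)c(-c3nn[nH]n3)c[nH]c12`, has not yet been measured. It differs from compound 3 in one place: methylsulfonyl in place of bromo on an aromatic carbon. For the measured compounds named here, no pair of measured compounds differing in a single place exists here, so the size of such a change cannot be read from the data. The expectation for compound 4 is a step of no more than modest size in either direction, with a fair chance that only a limit is reported again.

For compound 4 the estimate in this assay is 20 mg/kg, with a range from 5 mg/kg to 80 mg/kg, meaning an expected step that the limit leaves unreadable from compound 3 to compound 4.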

Compound 4, minimum effective dose: > 25 mg/kg
Compound 4: no number, only a limit; the forecaster's own chance of this, stated with the estimate: 60%; middle value at least 1.2-fold (0.09 log units) from the limit.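

In this assay, compound 3 and compound 4 each give only a limit of the assay and not a number, so the size of the step between them cannot be read. The compounds shown leave open how much of either compound is needed for an effect, and whether methylsulfonyl in place of bromo changes that dose at all.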